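Working notes: from 2-hydroxyphenyl to 3-hydroxyphenyl

The source may hold more compounds than are shown below. What is called first, only, known or untested is meant among the compounds shown, and "the series" means these compounds.

In a functional assay on PANC-1 cells (Homo sapiens) for inhibition, read by MTT assay, with a stated time of 24 h (a higher number here means a weaker inhibitor, a lower number a stronger inhibitor), two compounds on the shared core have been measured so far. Compound 1 `CC1(C)[C@H]2CC[C@]1(C)N(Cc1cn(-c3ccc(Br)cc3)nn1)C(=O)C2` gives 200 nM, and compound 2 `CC1(C)[C@H]2CC[C@]1(C)N(Cc1cn(-c3ccccc3O)nn1)C(=O)C2` gives 230 nM. For the measured compounds named here, compound 2 therefore stands level with compound 1, its only measured neighbour.

Compound 3 `CC1(C)[C@H]2CC[C@]1(C)N(Cc1cn(-c3cccc(O)c3)nn1)C(=O)C2` is still unmeasured. The change is 3-hydroxyphenyl in place of 2-hydroxyphenyl on an aromatic nitrogen of a five-membered aromatic ring with 3 nitrogen. The two compounds have the same atoms, joined differently.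

Going by the values given here, one measured step bears on this, at the same aromatic nitrogen: 2-hydroxyphenyl in place of 4-bromophenyl, which is a 1.2-fold higher number from compound 1 to compound 2 (0.06 log units; within the scatter). Among the compounds with values here, no measured pair compares 2-hydroxyphenyl with 3-hydroxyphenyl directly, so this evidence is indirect and rests on a single step. With that one exchange on the aromatic nitrogen staying within the scatter, no step beyond the scatter is expected in this assay, and no direction is favoured.

The expected step is a 1.1-fold higher number from compound 2 to compound 3 (0.04 log units; within the scatter). For compound 3 the estimate is 250 nM, with an expected range of 100 nM to 600 nM.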

Compound 3, half-maximal inhibitory concentration: 280 nM
Beside the measured number, compound 3's estimate is 1.1-fold (0.05 log units) below it, and the stated range covers the measured number.
By their numbers in this assay, from the lowest: compounds 1, 2 and 3 (each within the scatter of the next).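

For the compounds shown here, compound 3 gives the first direct comparison of two placements of the same hydroxyl group on the phenyl ring attached to the aromatic nitrogen. In this assay, 3-hydroxyphenyl in place of 2-hydroxyphenyl gives a 1.2-fold higher number from compound 2 to compound 3 (0.09 log units; within the scatter), so this shift of the hydroxyl, with the atoms unchanged, has no readable effect here. The exchange of 4-bromophenyl for 3-hydroxyphenyl gives a 1.4-fold higher number from compound 1 to compound 3 (0.15 log units; within the scatter), so compounds 1, 2 and 3 stand level in this assay, none going against that reading, and nothing available accounts for this flat result.

Going by these compounds alone, all three groups at this position are substituted phenyl rings, so it remains open whether a carboxylic acid or an amine on the ring, or a longer chain such as benzyl on the aromatic nitrogen, would stay within the same narrow band or produce the first step beyond the scatter. The level reading also rests on one cell line at one stated time, and it cannot show whether the three compounds would stay together under other conditions.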